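Cyano in place of nitro on the shared core

A few compounds are considered here, and "the series" means these few. Any claim that something is new, unique, unknown or untested is made for them only; others in the source may bear on it.

The series holds three measured compounds sharing the core of compound 1 `C#Cc1cccc(C#Cc2ccc(CCC(=O)O)cc2)c1`. In an in vitro functional assay on 1321-N1 cells for agonist activity at Free fatty acid receptor 1 (Homo sapiens), read by fluorescence (a lower number here means that less compound is needed, a higher number that more compound is needed for the effect), compound 1 gives 155 nM. Compound 2 `O=C(O)CCc1ccc(C#Cc2cccc([N+](=O)[O-])c2)cc1` gives 58.9 nM in this assay, and compound 3 `Cc1cccc(C#Cc2ccc(CCC(=O)O)cc2)c1C` gives 87.1 nM. Compound 2 stands at the lowest of the three numbers, but its gap to compound 3 lies within the scatter, so no order between those two is claimed; only compound 1 stands apart, as a 2.6-fold lower number from compound 1 to compound 2 (0.42 log units; beyond the scatter).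

Compound 4 `N#Cc1cccc(C#Cc2ccc(CCC(=O)O)cc2)c1` differs from compound 2 as follows: cyano in place of nitro on an aromatic carbon. Going by the values given here, the one measured step that bears on this position is the step from compound 1 to compound 2, a modest one. Among the compounds with values here, no measured pair shows cyano against nitro, so the direction of the present change is not fixed by the data; a step within the scatter in this assay is expected, as a 1.4-fold higher number from compound 2 to compound 4 (0.13 log units; within the scatter).

The estimate for compound 4 in this assay is therefore 80 nM, expected to fall between 30 nM and 220 nM.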

Compound 4, half-maximal effective concentration: 91.2 nM
The estimate for compound 4 lay 1.1-fold (0.06 log units) below the measured number; the range from low to high includes it.
By their numbers in this assay, from the lowest: compounds 2, 3, 4 and 1 (each within the scatter of the next, the first and the last beyond it).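

In this assay, cyano in place of nitro on this aromatic carbon gives a 1.5-fold higher number from compound 2 to compound 4 (0.19 log units; within the scatter), and cyano in place of ethynyl gives a 1.7-fold lower number from compound 1 to compound 4 (0.23 log units; within the scatter). The earlier compounds shown here showed one separation at this position, between ethynyl and nitro; cyano lies within the scatter of both, so this third group cannot be placed apart from either, even though those two stand apart. Nothing at hand accounts for these numbers.

Open, on these data alone, is whether a group of another kind on this carbon, such as an amine or a methoxy group, would move the number beyond the scatter of compound 2. Also open, as far as these compounds go, is whether cyano would give a similar number on another carbon of the same ring.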